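The source may report more compounds than this note shows. Statements on the series, on what has been measured and on what is new or still open speak of the compounds shown alone.

Measured so far in a functional assay on the whole organism for inhibition, with Rattus norvegicus as the target; on this read-out lower numbers stand for an effect already at smaller amounts and higher numbers for an effect only at larger amounts of compound:
compound 1 `CC1CCCc2ncc(C(=O)O)c(=O)n21` gives 240 umol/kg
compound 2 `O=C(O)c1cnc2n(c1=O)CCC/C2=N\Nc1ccccc1` gives 31.6 umol/kg
compound 3 `CC1CC/C(=N\Nc2ccccc2F)c2ncc(C(=O)O)c(=O)n21` gives 5 umol/kg

Compound 3 has the lowest number of the three. Compound 2 stands closest to it, and that gap is beyond the usual scatter, as is the larger gap to compound 1. The unmeasured compound 4 `CC1CC/C(=N\Nc2cccc(Cl)c2)c2ncc(C(=O)O)c(=O)n21` differs from compound 3 in one place: 3-chlorophenyl in place of 2-fluorophenyl on an amine nitrogen. For the measured compounds named here, no measured pair shows a change of this kind, so there is nothing to gauge its size against. A small shift in this assay, in either direction, or none beyond the scatter, is what can be expected. The expected step is a 1.6-fold higher number from compound 3 to compound 4 (0.20 log units; within the scatter). Compound 4 is therefore estimated at 8 umol/kg, with a range from 2 umol/kg to 30 umol/kg.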

Compound 4, dose for 50% inhibition: 0.6 umol/kg
Beside the measured number, compound 4's estimate is 13-fold (1.12 log units) above it; measured number below the stated range.
By their numbers in this assay, from the lowest: compound 4; then compound 3; then compound 2; then compound 1.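

In this assay, for the compounds shown here, the group on this amine nitrogen clearly matters: 3-chlorophenyl in place of 2-fluorophenyl gives an 8.3-fold lower number from compound 3 to compound 4 (0.92 log units; beyond the scatter) and this is the first single-place change. The swap alters both the halogen and where it sits, so the step cannot be assigned to either alone. No measurement here explains the step.

The compounds shown leave open whether 2-chlorophenyl or 3-fluorophenyl would separate those two changes. They also leave open how 3-methoxyphenyl or 3-aminophenyl would compare with 3-chlorophenyl at this position.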